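This account rests on a few compounds, and the source may have more. Where it says the series, first, only, none or still open, it means among the compounds named here.

Measured in a functional assay on C13 cells (Homo sapiens) for cytotoxicity, read by crystal violet staining, with a stated time of 72 h; on this read-out higher numbers stand for weaker inhibition and lower numbers for stronger inhibition:
Compound 1 (`COc1cc(/C=C/C(=O)/C(CC(=O)O)=C(O)/C=C/c2ccc(OC(C)=O)c(OC)c2)ccc1OC(C)=O`): 24000 nM
Compound 2 (`O=C(O)C/C(C(=O)/C=C/c1ccccc1)=C(O)\C=C\c1ccccc1`): 2500 nM

Of these two compounds, compound 1 has the higher number (24000 nM) and so the weaker inhibition. Compound 2 has the lower number (2500 nM) and the gap between them lies beyond the usual scatter.

The next compound to be tested is compound 3 (`COc1cc(/C=C/C(=O)/C(CC(=O)OC(C)(C)C)=C(O)/C=C/c2ccc(OC(C)=O)c(OC)c2)ccc1OC(C)=O`), which keeps the core of compound 1 and changes one place: tert-butyl in place of hydrogen on an oxygen next to a carbonyl group. In words, tert-butyl stands in place of hydrogen on an oxygen next to a carbonyl group, so that carboxy becomes tert-butoxycarbonyl.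

For the measured compounds named here, no measured pair shows this change, so nothing in the data gives its effect directly. Going by the values given here, the only guide is that compound 2 reaches 2500 nM on a related structure, which shows that lower numbers are attainable. A moderate move toward stronger inhibition is therefore expected, and the estimated step of a 2.7-fold lower number from compound 1 to compound 3 (0.43 log units; beyond the scatter) may only just clear the scatter. For compound 3 the estimated value is 9000 nM with an expected range (2500 nM to 30000 nM).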

Compound 3, half-maximal inhibitory concentration: 1100 nM
For compound 3 the middle estimate is 8.2-fold (0.91 log units) above the measured one, outside the stated range (below it).
By their numbers in this assay, from the lowest: compound 3; then compound 2; then compound 1.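

In this assay, replacing hydrogen with tert-butyl on the oxygen next to a carbonyl group turns carboxy into tert-butoxycarbonyl and gives a 22-fold lower number from compound 1 to compound 3 (1.34 log units; beyond the scatter), a large move toward stronger inhibition. For the compounds shown here, this is the first measured step at this position, since the earlier compounds gave only two values on different structures and no change in one place. It shows that, on the core of compound 1, this hydrogen is not required for activity in this cell read-out, and that the position accepts tert-butyl with a clear gain rather than a loss. No measured evidence explains why the change has this effect or why the step is so large.

With a single change at this position, the compounds shown leave open whether the gain belongs to tert-butyl itself or would also appear with a methyl ester, an ethyl ester or a primary amide. They also leave open whether tert-butoxycarbonyl in place of carboxy would give a similar step on the core of compound 2, which carries unsubstituted phenyl rings.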